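Replacing the cyanophenyl arm of compound 1 with a branched alkyl

The source may hold more compounds than are shown below. What is called first, only, known or untested is meant among the compounds shown, and "the series" means these compounds.

The series shares a carboxylic acid-bearing biaryl attached through a two-carbon linker to an imidazole core, with the variable arm on the other side of that core. In an in vitro functional assay on cells for agonist activity at Bombesin receptor subtype-3 (Mus musculus), read by luminescence and calcium flux (a higher number here means that more compound is needed for the effect, a lower number that less compound is needed), compound 1 `N#Cc1cccc(Cc2cnc(CCc3ccc(-c4ccccc4C(=O)O)cc3)[nH]2)c1` gives 20 nM, the lowest of the two numbers recorded. Compound 3 `CCCCc1cnc(/C=C/c2ccc(-c3ccccc3C(=O)O)cc2)[nH]1` gives 10000 nM in this assay, a far higher number, and the gap to compound 1 is beyond the scatter. Compound 2 `CCCCc1cnc(Cc2ccc(-c3ccccc3C(=O)O)cc2)[nH]1` reaches only the limit of this assay, > 10000 nM; that is a limit and not a number, as noted in the limit of > 10000 nM in this assay, at which 1 of the 3 values shown sits. Neither compound 2 nor compound 3 differs from compound 1 in one place alone, so no single step can be read from them.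

Compound 4 `CCC(C)(CC)Cc1cnc(CCc2ccc(-c3ccccc3C(=O)O)cc2)[nH]1` has not been measured. It differs from compound 1 by 1-ethyl-1-methylpropyl in place of 3-cyanophenyl on a saturated chain carbon bound to an aromatic carbon. Within the data shown here, no measured step of this kind exists here. The expectation is a clear loss, with the step from compound 1 to compound 4 estimated at a 75-fold higher number from compound 1 to compound 4 (1.88 log units; beyond the scatter). Compound 4 is thus expected to give about 1500 nM in this assay, within a range from 150 nM to 10000 nM, with a real chance that only a limit is returned.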

Compound 4, half-maximal effective concentration: 30 nM
The estimate for compound 4 lay 50-fold (1.70 log units) above the measured number; measured number outside the range, below it.
By their numbers in this assay, from the lowest: compounds 1 and 4 (each within the scatter of the next); then compound 3.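

In this assay, among these compounds, the step of a 1.5-fold higher number from compound 1 to compound 4 (0.18 log units; within the scatter) is the first reading at this position, on a saturated chain carbon bound to an aromatic carbon, and it comes from replacing 3-cyanophenyl with 1-ethyl-1-methylpropyl. Compound 1 and compound 4 therefore show that neither the aromatic ring nor the nitrile of 3-cyanophenyl is needed here to keep the number in the same range, since a group with no ring, no triple bond and no hydrogen-bond acceptor serves within the scatter. Nothing measured in the data accounts for this tolerance.

From the compounds shown here alone, the reach of this tolerance stays open: a primary amine, a carboxylic acid or a cyclohexyl ring in the same place would test whether the position accepts more than these two arms. An unbranched chain on the linker of compound 1 also remains to be read, as compound 2 and compound 3 differ from compound 1 in more than one place and their steps cannot be read.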